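The source may report more compounds than this note shows. Statements on the series, on what has been measured and on what is new or still open speak of the compounds shown alone.

In a functional assay on U-937 cells (Homo sapiens) for cytotoxicity, read by MTT assay, with a stated time of 24 h (a lower number here means a stronger inhibitor, a higher number a weaker inhibitor), three compounds sharing one core have been measured so far. Compound 1 `BrCCCOc1c(Br)cc(Br)cc1Oc1ccc(Br)cc1Br` gives 30.3 ug/mL, compound 2 `CN1CCN(CCCCCOc2c(Br)cc(Br)cc2Oc2ccc(Br)cc2Br)CC1` gives 49.1 ug/mL, and compound 3 `OCCCOc1c(Br)cc(Br)cc1Oc1ccc(Br)cc1Br` gives 32.3 ug/mL. Compound 3 therefore stands level with the other two, its value lying within the scatter of both.

The next compound, compound 4 `CC(=O)Oc1c(Br)cc(Br)cc1Oc1ccc(Br)cc1Br`, differs from compound 3 by acetyl in place of 3-hydroxypropyl on an oxygen on an aromatic ring.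

The measured steps bear on this change only indirectly, as each alters a saturated chain carbon three bonds along the chain from that oxygen: a 1.6-fold higher number from compound 1 to compound 2 (0.21 log units; within the scatter), a 1.1-fold higher number from compound 1 to compound 3 (0.03 log units; within the scatter) and a 1.5-fold lower number from compound 2 to compound 3 (0.18 log units; within the scatter). All three lie within the scatter. Among the measured compounds shown here, none of them replaces the whole chain with acetyl, so the data offer no direct precedent, and they favour no direction. Judging from the size of a 1.5-fold lower number from compound 2 to compound 3 (0.18 log units; within the scatter) and a 1.1-fold higher number from compound 1 to compound 3 (0.03 log units; within the scatter), no step beyond the scatter is expected in this assay. The expected size is a 1.1-fold lower number from compound 3 to compound 4 (0.03 log units; within the scatter). For compound 4 the estimated value is 30 ug/mL, with an expected range from 15 ug/mL to 58 ug/mL.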

Compound 4, half-maximal inhibitory concentration: 32.3 ug/mL
Estimate against measurement, compound 4: 1.1-fold (0.03 log units) below, within the range that was stated.
By their numbers in this assay, from the lowest: compounds 1, 3, 4 and 2 (each within the scatter of the next).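

Until now the steps had altered only the end of the chain on this oxygen, whereas here the whole 3-hydroxypropyl gives way to acetyl, and in this assay this brings no change at the digits printed from compound 3 to compound 4 (within the scatter). Set against the bromo-ended chain, the same acetyl gives a 1.1-fold higher number from compound 1 to compound 4 (0.03 log units; within the scatter), so neither comparison separates acetyl from the propyl chains on the oxygen on an aromatic ring, even though the change shortens the group, removes the hydrogen-bond donor of 3-hydroxypropyl and adds a double bond outside aromatic rings. No outside information on these compounds accounts for this flat reading, and the numbers alone cannot explain it.

All four compounds lie within the scatter of the next in order, leaving open whether any group on this oxygen can produce a step beyond the scatter, such as a carboxylic acid, a primary amine, a much longer chain or a bare hydroxy in place of the whole substituent. On these data alone, the bromo groups stay the same throughout, so how the shared core itself contributes to these numbers also remains open.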